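The source may report more compounds than this note shows. Statements on the series, on what has been measured and on what is new or still open speak of the compounds shown alone.

Measured in a functional assay for binding affinity, with Homo sapiens as the target, read by fluorescence and flow cytometry; on this read-out lower numbers stand for tighter binding and higher numbers for weaker binding:
Compound 1 `O=C(NC[C@H](NS(=O)(=O)c1ccccc1)C(=O)O)c1cc2cc(CCC3CCNCC3)sc2s1` gives 0.023 nM
Compound 2 `CCCCS(=O)(=O)N[C@@H](CNC(=O)c1cc2cc(CCC3CCNCC3)sc2s1)C(=O)O` gives 5.6 nM
Compound 3 `O=C(NC[C@H](NS(=O)(=O)c1ccccc1)C(=O)O)c1cc2sc(CCC3CCNCC3)cc2s1` gives 0.15 nM

Compound 1 and compound 2 share a core and differ in one place: butyl in place of phenyl on a sulfonyl sulfur. That change brought a 240-fold higher number from compound 1 to compound 2 (2.39 log units; beyond the scatter). Compound 3 is built from the same atoms as compound 1, joined differently; the difference between the two cores is not broken down here. In this assay compound 3 sits between the other two, with a number higher than compound 1 and lower than compound 2, both gaps beyond the scatter.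

Compound 4 `CCCCS(=O)(=O)N[C@@H](CNC(=O)c1cc2sc(CCC3CCNCC3)cc2s1)C(=O)O` has not yet been measured. It stands to compound 3 as compound 2 stands to compound 1: butyl in place of phenyl on a sulfonyl sulfur. Since the place of the change is the same in both pairs, the same change is made on the core of compound 3. Going by the values given here, the step from compound 3 to compound 4 is expected to be large and in the same direction as the one seen between compound 1 and compound 2, estimated at a 240-fold higher number from compound 3 to compound 4 (2.38 log units; beyond the scatter), because that earlier pair gave a 240-fold higher number from compound 1 to compound 2 (2.39 log units; beyond the scatter). On that basis compound 4 is estimated at 36 nM in this assay, with a likely range from 8 nM to 150 nM.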

Compound 4, dissociation constant: 3 nM
Estimate against measurement, compound 4: 12-fold (1.08 log units) above, and the stated range ends above it.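

Butyl in place of phenyl on a sulfonyl sulfur again weakened binding in this assay, with a 20-fold higher number from compound 3 to compound 4 (1.30 log units; beyond the scatter) in the same direction as on the core of compound 1. The size of the step, however, did not carry over from one core to the other: the same change on two cores in this assay, a 240-fold higher number (2.39 log units; beyond the scatter) from compound 1 to compound 2 and a 20-fold higher number (1.30 log units; beyond the scatter) from compound 3 to compound 4, 12-fold (1.09 log units) apart, beyond the scatter of two such steps. In this series, then, the two pairs agree on the direction of the change but not on its size, and they do not show why the size differs or how large the step would be on any further core.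

The compounds shown leave open whether a longer chain than butyl, or a benzyl group, on the sulfonyl sulfur would also give a step in this direction on both cores. They also leave open whether the gap between the two cores would persist if an amide or an ester took the place of the carboxylic acid.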